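The source may report more compounds than this note shows. Statements on the series, on what has been measured and on what is new or still open speak of the compounds shown alone.

Working notes on the series. In a functional assay on SK-MEL-28 cells (Homo sapiens) for cytotoxicity, read by sulforhodamine B assay, with a stated time of 48 h (on this read-out higher numbers stand for lower toxicity in this test and lower numbers for higher toxicity in this test), compound 1 `ClCc1cccc(Cn2cnc3c(Cl)ncnc32)c1` gives 28800 nM. Compound 2 `ClCc1cccc(Cn2cnc3c(Cl)nc(Cl)nc32)c1` differs from compound 1 by chloro in place of hydrogen on an aromatic carbon. In this assay compound 2 reaches only the limit of > 100000 nM, a limit and not a number. The measured step is accordingly an at least 3.4-fold higher number from compound 1 to compound 2 (0.54 log units; beyond the scatter), its size resting on (the limit of > 100000 nM in this assay, at which 1 of the 3 values shown sits). Compound 3 `ClCc1ccccc1Cn1cnc2ncnc(Cl)c21` is built from the same atoms as compound 1, joined differently; the difference between the two cores is not broken down here. In this assay compound 3 gives 79400 nM, the highest of the two numbers available, with compound 1 the nearest. Compound 4 `ClCc1ccccc1Cn1cnc2nc(Cl)nc(Cl)c21` differs from compound 3 by chloro in place of hydrogen on an aromatic carbon, the same change as that from compound 1 to compound 2, made at the same place. For compound 4 the expected step is a 3.1-fold higher number from compound 3 to compound 4 (0.50 log units; beyond the scatter), beside the earlier one, because the measured step of an at least 3.4-fold higher number from compound 1 to compound 2 (0.54 log units; beyond the scatter) already carried the starting number past the limit (the limit of > 100000 nM in this assay, at which 1 of the 3 values shown sits). Compound 4 is therefore estimated at 250000 nM, between 90000 nM and 800000 nM, and most likely this assay will report only a limit for it.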

Compound 4, concentration lethal to 50% of the cells: > 100000 nM
Compound 4: a limit, no number; the forecaster's own chance of this, stated with the estimate: 80%; the middle value does not contradict the limit.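

In this assay compound 4 gives > 100000 nM, a limit and not a number. On the core of compound 3, chloro in place of hydrogen on an aromatic carbon gives an at least 1.2-fold higher number from compound 3 to compound 4 (0.10 log units; that floor lies within the scatter), which fits the direction of the earlier step but does not establish a change beyond the scatter on this core. The change can therefore be carried to the second core without contradiction, but neither a matching nor a differing size is shown: the same change on two cores in this assay, an at least 3.4-fold higher number (0.54 log units; beyond the scatter) from compound 1 to compound 2 and an at least 1.2-fold higher number (0.10 log units; that floor lies within the scatter) from compound 3 to compound 4; the limit leaves it open whether they differ

From the compounds shown here alone, what an amine or a methoxy group would give at this place, on either core, stays open. The actual size of both steps also stays open, as the two compounds carrying the added chloro give no number to compare: the limit of > 100000 nM in this assay, at which 2 of the 4 values shown sit.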